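A few compounds are considered here, and "the series" means these few. Any claim that something is new, unique, unknown or untested is made for them only; others in the source may bear on it.

In a functional assay on MGC-803 cells (Homo sapiens) for inhibition, read by MTT assay, with a stated time of 72 h (a lower number here means a stronger inhibitor, a higher number a weaker inhibitor), the measured compounds give:

compound 1 `O=C(Nc1ccccc1)C1CCN(C/C=C/c2ccccc2)CC1` gives 57900 nM
compound 2 `COc1ccc(NC(=O)C2CCN(C/C=C/c3ccccc3)CC2)cc1` gives 58200 nM
compound 3 `O=C(Nc1cccc(C(F)(F)F)c1)C1CCN(C/C=C/c2ccccc2)CC1` gives 9590 nM

Compound 3 has the lowest number of the three, and its gap to each of the others lies beyond the scatter. Compound 4 `O=C(Nc1cccc(Br)c1)C1CCN(C/C=C/c2ccccc2)CC1` has bromo in place of trifluoromethyl on an aromatic carbon. Among the compounds with values here, two measured steps bear on this. Adding trifluoromethyl gave a 6.0-fold lower number from compound 1 to compound 3 (0.78 log units; beyond the scatter), while adding methoxy gave a 1.0-fold higher number from compound 1 to compound 2 (0.00 log units; within the scatter), so not every added group lowers the number. Within the data shown here, no bromo compound has been measured, so the size of the change is uncertain. In this assay a small move to a higher number, within the scatter, is expected. The expected change is a 1.4-fold higher number from compound 3 to compound 4 (0.13 log units; within the scatter). For compound 4 the estimated value is 13000 nM, with an expected range of 5500 nM to 30000 nM.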

Compound 4, half-maximal inhibitory concentration: 9110 nM
The estimate for compound 4 lay 1.4-fold (0.15 log units) above the measured number; the measured number falls inside the stated range.
By their numbers in this assay, from the lowest: compounds 4 and 3 (each within the scatter of the next); then compounds 1 and 2 (each within the scatter of the next).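

In this assay, bromo replaces trifluoromethyl on this aromatic carbon with no change beyond the scatter (a 1.1-fold lower number from compound 3 to compound 4 (0.02 log units; within the scatter)). The lower number of compound 3 is therefore not unique to trifluoromethyl, as bromo alone also lowers the number relative to the unsubstituted ring (a 6.4-fold lower number from compound 1 to compound 4 (0.80 log units; beyond the scatter)) and relative to the 4-methoxyphenyl compound (a 6.4-fold lower number from compound 2 to compound 4 (0.81 log units; beyond the scatter)). Nothing measured here explains why these two groups give matching numbers. From the compounds shown here alone, whether a nitrile or a carboxylic acid at this same place would match them remains open. So does whether bromo elsewhere on the ring would keep the lower number.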